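Fluoro in place of methyl on compound 1

This account rests on a few compounds, and the source may have more. Where it says the series, first, only, none or still open, it means among the compounds named here.

In a functional assay on A549 cells (Homo sapiens) for antiproliferative activity, read by MTT assay, with a stated time of 48 h (a lower number here means a stronger inhibitor, a higher number a weaker inhibitor), compound 1 (`Cc1ccc(C(=O)/C=C/c2cc(Br)cc(Br)c2Oc2c([N+](=O)[O-])cc(C(F)(F)F)cc2[N+](=O)[O-])cc1`) gives 10.1 ug/mL and compound 2 (`Cc1ccc(C(=O)/C=C/c2cccc(Br)c2Oc2c([N+](=O)[O-])cc(C(F)(F)F)cc2[N+](=O)[O-])cc1`) gives 6.85 ug/mL as its value, so the two stand within the scatter of each other. Compound 3 (`O=C(/C=C/c1cc(Br)cc(Br)c1Oc1c([N+](=O)[O-])cc(C(F)(F)F)cc1[N+](=O)[O-])c1ccc(F)cc1`) has not yet been measured. It departs from compound 1 by fluoro in place of methyl on an aromatic carbon as a single change, fluoro in place of methyl on an aromatic carbon. Among the compounds with values here, only one measured step is at hand, a 1.5-fold lower number from compound 1 to compound 2 (0.17 log units; within the scatter) for hydrogen in place of bromo, and it concerns a different group. Within the data shown here, no measured pair changes the 4-methylphenyl group, so the data give no direction for this swap. The expected change in this assay is therefore none beyond the scatter, with a 1.1-fold lower number from compound 1 to compound 3 (0.05 log units; within the scatter) as the estimated step. For compound 3 the estimated value is 9 ug/mL as the middle, with an expected range from 4 ug/mL to 19 ug/mL around it.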

Compound 3, half-maximal inhibitory concentration: 120 ug/mL
Beside the measured number, compound 3's estimate is 13-fold (1.12 log units) below it; measured number outside the range, above it.
By their numbers in this assay, from the lowest: compounds 2 and 1 (each within the scatter of the next); then compound 3.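

In this assay the 4-methylphenyl group turns out to be a sensitive place: fluoro in place of methyl, one heavy atom for one with no ring or net charge involved, gives a 12-fold higher number from compound 1 to compound 3 (1.07 log units; beyond the scatter). The only earlier step, a 1.5-fold lower number from compound 1 to compound 2 (0.17 log units; within the scatter), stayed within the scatter, so this is the first single change shown to move the number beyond it, and it moves toward weaker inhibition. Nothing at hand bears on why so small a swap has so large an effect.

The compounds shown carry only methyl and fluoro at this place, so it stays open whether the same swap on compound 2 gives a step of like size. On these data alone, how chloro, methoxy or an amine on that aromatic carbon would read in this assay also stays open.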